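Trading One Saturated Ring for Another on a Sulfonyl Sulfur

The source may hold more compounds than are shown below. What is called first, only, known or untested is meant among the compounds shown, and "the series" means these compounds.

In a physicochemical assay for solubility, in phosphate buffer, with a stated time of 24 h, at pH 7.4, tested at 100 uM (on this read-out lower numbers stand for lower solubility and higher numbers for higher solubility), compound 1 `O=C(NCc1ccc(S(=O)(=O)c2cccc(C(F)(F)F)c2)cc1)N1Cc2ccncc2C1` gives 10000 nM as its reading. For the measured compounds named here, compound 2 `O=C(NCc1ccc(S(=O)(=O)C2CCOCC2)cc1)N1Cc2ccncc2C1` gives 206000 nM and holds the higher of the two numbers so far. Compound 3 `CN1CCC(S(=O)(=O)c2ccc(CNC(=O)N3Cc4ccncc4C3)cc2)CC1` keeps the core of compound 2 and has not yet been measured. Going by the values given here, the single change is 1-methylpiperidin-4-yl in place of oxan-4-yl on a sulfonyl sulfur and it reads in words as 1-methylpiperidin-4-yl in place of oxan-4-yl on a sulfonyl sulfur. Among the compounds with values here, only one measured step bears on this, and only loosely: a 21-fold higher number from compound 1 to compound 2 (1.31 log units; beyond the scatter) is large and beyond the scatter. It came with oxan-4-yl in place of 3-(trifluoromethyl)phenyl on a sulfonyl sulfur. That swap replaced an aromatic group with a non-aromatic ring, whereas here one six-membered non-aromatic ring replaces another. Within the data shown here, no measured compound yet carries 1-methylpiperidin-4-yl, so the direction stays open. With compound 2 at 206000 nM as the closest guide, no step beyond the scatter is expected in this assay for this change. The estimated step is a 1.1-fold higher number from compound 2 to compound 3 (0.03 log units; within the scatter) and it stays within that scatter. For compound 3 the estimated value is 220000 nM with an expected range of 100000 nM to 450000 nM in repeated measurements.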

Compound 3, solubility: 240000 nM
For compound 3 the middle estimate is 1.1-fold (0.04 log units) below the measured one, and the stated range covers the measured number.
By their numbers in this assay, from the lowest: compound 1; then compounds 2 and 3 (each within the scatter of the next).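

In this assay, the step to 1-methylpiperidin-4-yl from oxan-4-yl on the sulfonyl sulfur is a 1.2-fold higher number from compound 2 to compound 3 (0.07 log units; within the scatter), so this read-out does not separate these two six-membered non-aromatic rings, even though one holds an oxygen and the other a nitrogen bearing a methyl group. Against 3-(trifluoromethyl)phenyl, the step is a 24-fold higher number from compound 1 to compound 3 (1.38 log units; beyond the scatter), large like the earlier 21-fold higher number from compound 1 to compound 2 (1.31 log units; beyond the scatter), which shows that the large step is not unique to oxan-4-yl: two different non-aromatic rings now both stand well beyond the scatter of compound 1. Nothing available explains why these two rings read alike or why both differ so much from the aromatic group.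

Only two non-aromatic rings are shown, both six-membered and each with one hetero atom, so the result says nothing yet about a cyclohexyl ring, which has no hetero atom, or an open chain such as ethyl. The steps from compound 1 also change two things together, the aromatic ring and its trifluoromethyl group, and a plain phenyl group on the same sulfur would be needed to tell those two apart.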